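Pyrrolidine in Place of Morpholine on the Urea Carbonyl

This account rests on a few compounds, and the source may have more. Where it says the series, first, only, none or still open, it means among the compounds named here.

Among the compounds with values here, compound 2 `COc1ccc(/C(=C(/CCNC(=O)N2CCOCC2)c2ccccc2)c2ccccc2)cc1` gives 42800 nM in a functional assay on MDA-MB-231 cells (Homo sapiens) for cytotoxicity, read by MTT assay, with a stated time of 72 h (on this read-out higher numbers stand for weaker inhibition and lower numbers for stronger inhibition), and this is the only number in the small set. Compound 1 `COc1ccc(/C(=C(/CCNC(=O)NC2CCCCC2)c2ccccc2)c2ccccc2)cc1` is reported in this assay only as a limit, > 50000 nM, at the limit of > 50000 nM in this assay, at which 1 of the 2 values shown sits. The single measured step, an at least 1.1-fold lower number from compound 1 to compound 2 (0.06 log units; that floor lies within the scatter), runs from that limit and stays within the scatter, so the carbonyl substituent has so far shown no effect that can be read as a number.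

Compound 3 `COc1ccc(/C(=C(/CCNC(=O)N2CCCC2)c2ccccc2)c2ccccc2)cc1` differs from compound 2 by pyrrolidin-1-yl in place of morpholin-4-yl on a carbonyl carbon. Within the data shown here, no measured step covers this particular exchange, and the one step that does touch the carbonyl substituent is flat. For compound 3 the expected step is therefore a 1.1-fold lower number from compound 2 to compound 3 (0.03 log units; within the scatter), no change beyond the scatter. Compound 3 is estimated to give 40000 nM in this assay, with a range from 15000 nM to 100000 nM, and a real chance that only a limit is reported.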

Compound 3, half-maximal inhibitory concentration: > 50000 nM
Compound 3: no number, only a limit; the forecaster's own chance of this, stated with the estimate: 40%; middle value at least 1.2-fold (0.09 log units) from the limit.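

In this assay compound 3 is reported only as a limit, > 50000 nM. Pyrrolidin-1-yl in place of morpholin-4-yl on a carbonyl carbon gives an at least 1.1-fold higher number from compound 2 to compound 3 (0.06 log units; that floor lies within the scatter), so a second exchange at this position also shows no difference beyond the scatter, and the step between the two limits cannot be read. The three carbonyl substituents shown therefore give no readable separation, and most of the set now rests on one limit: the limit of > 50000 nM in this assay, at which 2 of the 3 values shown sit.

Going by these compounds, it remains open whether any other group on this carbonyl carbon, such as piperazin-1-yl, dimethylamino or phenylamino, would give a number clearly lower than that of compound 2. The limits also leave open how far compound 1 and compound 3 actually differ from each other.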